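Lengthening the ester chain of compound 2 by one carbon

A few compounds are considered here, and "the series" means these few. Any claim that something is new, unique, unknown or untested is made for them only; others in the source may bear on it.

Compound 2 `CCOC(=O)CCSc1nc2ccccc2n1CC(=O)O` gives 11400 nM in an assay on HEK293 cells for displacement of a labelled ligand from prostaglandin D2 receptor 2 (Homo sapiens); on this read-out higher numbers stand for weaker inhibition and lower numbers for stronger inhibition. Within the data shown here, of the two numbers known in this assay, this is the highest; its nearest neighbour, compound 1 `O=C(O)Cn1c(SCCCc2ccccc2)nc2ccccc21`, gives 475 nM. Among the measured compounds shown here, the only step known is a 24-fold higher number from compound 1 to compound 2 (1.38 log units; beyond the scatter), which exchanges one group for another at the same position and leaves the chain length untouched. Compound 3 `CCOC(=O)CCCSc1nc2ccccc2n1CC(=O)O` differs from compound 2 in a different way: (ethoxycarbonyl)methyl in place of ethoxycarbonyl on a saturated chain carbon, two bonds along the chain from a sulfur. For the measured compounds named here, no measured pair shows a chain lengthened by a single carbon, so the measured step bears on this change only loosely, and nothing in the data points to a shift beyond the scatter in either direction. Compound 3 is therefore expected to give about 9000 nM in this assay, with a range of 3000 nM to 27000 nM. The estimated step of a 1.3-fold lower number from compound 2 to compound 3 (0.10 log units; within the scatter) is accordingly taken to be small.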

Compound 3, half-maximal inhibitory concentration: 4410 nM
Estimate against measurement, compound 3: 2.0-fold (0.31 log units) above; the measured number falls inside the stated range.
By their numbers in this assay, from the lowest: compound 1; then compound 3; then compound 2.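

In this assay, the position proves sensitive to chain length alone: (ethoxycarbonyl)methyl in place of ethoxycarbonyl, one carbon more with the ester kept, gives a 2.6-fold lower number from compound 2 to compound 3 (0.41 log units; beyond the scatter). This recovers only part of the loss seen in a 24-fold higher number from compound 1 to compound 2 (1.38 log units; beyond the scatter), and the ester still falls well short of the phenyl end group, with ethoxycarbonyl in place of phenyl giving a 9.3-fold higher number from compound 1 to compound 3 (0.97 log units; beyond the scatter). No supporting data are available to explain why the added carbon changes the number.

On these data alone, with only this one lengthening in hand, it remains open whether a longer chain ending in the same ethyl ester would continue the change or reverse it. As far as these compounds go, it is equally open how a carboxylic acid or an amide at the chain end would compare with the ester and with phenyl.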